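This account rests on a few compounds, and the source may have more. Where it says the series, first, only, none or still open, it means among the compounds named here.

Measured compounds in a functional assay on U-373MG ATCC cells (Homo sapiens) for inhibition, read by colorimetric assay and MTT assay, with a stated time of 72 h; a higher number here means a weaker inhibitor, a lower number a stronger inhibitor:
compound 1 `COc1ccc(-c2cc(NC(=S)NNC(=O)c3ccc(C)cc3)cs2)cc1`; compound 2 `Cc1ccc(C(=O)NNC(=S)Nc2csc(-c3ccccc3)c2)cc1`, giving 62000 nM; compound 3 `Cc1ccc(C(=O)NNC(=S)Nc2csc(-c3ccc(C)cc3)c2)cc1`, giving 38000 nM. For compound 1 only a limit is reported, > 100000 nM (the limit of > 100000 nM in this assay, at which 1 of the 3 values shown sits).

Compound 3 holds the lowest of the two numbers, with compound 2 nearest: a 1.6-fold lower number from compound 2 to compound 3 (0.21 log units; within the scatter). The step of an at least 2.6-fold lower number from compound 1 to compound 3 (0.42 log units; beyond the scatter) runs against a limit, as does an at least 1.6-fold lower number from compound 1 to compound 2 (0.20 log units; that floor lies within the scatter).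

Compound 4 `Cc1ccc(-c2cc(NC(=S)NNC(=O)c3ccc(O)cc3)cs2)cc1` differs by hydroxy in place of methyl on an aromatic carbon. Within the data shown here, none of the measured steps touches the 4-methylphenyl that this change alters; they vary another ring and move the number little or only against the limit. Compound 4 is therefore expected to show a 1.3-fold higher number from compound 3 to compound 4 (0.12 log units; within the scatter), no shift beyond the scatter, with the estimate 50000 nM within 20000 nM to 150000 nM.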

Compound 4, half-maximal inhibitory concentration: 64000 nM
For compound 4 the middle estimate is 1.3-fold (0.11 log units) below the measured one; measured number inside the range.
By their numbers in this assay, from the lowest: compounds 3, 2 and 4 (each within the scatter of the next). At a limit, above all of these: compound 1.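

In this assay, among these compounds, the change from 4-methylphenyl to 4-hydroxyphenyl gives a 1.7-fold higher number from compound 3 to compound 4 (0.23 log units; within the scatter) and so, unlike the earlier steps on the other ring, probes this ring directly. At this place, one hydrogen-bond donor and one hydrogen-bond acceptor enter without a step beyond the scatter. Nothing on hand bears on the reason for this step.

Still open, as far as these compounds go, is whether an amine or a carboxylic acid at this place would give a step beyond the scatter. Also open, from the compounds shown here alone, is whether a longer chain there would do so.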